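Demethylation of compound 3 in the nucleoside series

The source may hold more compounds than are shown below. What is called first, only, known or untested is meant among the compounds shown, and "the series" means these compounds.

Compound 1 `OC[C@H]1O[C@@H](n2cnc3c(NCc4ccccc4Cl)ncnc32)[C@H](O)[C@@H]1O` is the reference point of the series. In a functional assay on K562 cells (Homo sapiens) for antiproliferative activity, with a stated time of 72 h (on this read-out lower numbers stand for stronger inhibition and higher numbers for weaker inhibition), compound 1 gives 64000 nM. Compound 2 `COc1cccc(CNc2ncnc3c2ncn3[C@@H]2O[C@H](CO)[C@@H](O)[C@H]2O)c1` carries 3-methoxyphenyl in place of 2-chlorophenyl. In this assay compound 2 reaches only the limit of the assay, > 166000 nM. Compound 3 `COc1cccc(CNc2ncnc3c2ncn3[C@@H]2O[C@H](CO)[C@@H](O)[C@H]2O)c1OC` carries 2,3-dimethoxyphenyl. In this assay compound 3 likewise sits at the limit of the assay, > 166000 nM. Compound 3 thus stands at the weak end of what has been measured: an at least 2.5-fold higher number from compound 1 to compound 3 (0.41 log units; beyond the scatter), matching an at least 2.5-fold higher number from compound 1 to compound 2 (0.41 log units; beyond the scatter). The step that the two limits leave unreadable from compound 2 to compound 3 cannot be read because the limit of > 166000 nM in this assay, at which 2 of the 3 values shown sit, is where both of its ends sit.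

Compound 4 `COc1cccc(CNc2ncnc3c2ncn3[C@@H]2O[C@H](CO)[C@@H](O)[C@H]2O)c1O` differs from compound 3 by hydrogen in place of methyl on an oxygen on an aromatic ring. Within the data shown here, no measured step exchanges methoxy for hydroxy, and the only step touching a methoxy is unreadable, so there is no basis for expecting a move beyond the scatter in this assay. Compound 4 is therefore estimated to remain at or near the limit, expected at 200000 nM, with a range from 70000 nM to 600000 nM. The expected step that the limit leaves unreadable from compound 3 to compound 4 is none beyond the scatter.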

Compound 4, half-maximal inhibitory concentration: 27900 nM
The estimate for compound 4 lay 7.2-fold (0.86 log units) above the measured number; measured number outside the range, below it.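

In this assay, hydrogen in place of methyl on an oxygen on an aromatic ring gives an at least 5.9-fold lower number from compound 3 to compound 4 (0.77 log units; beyond the scatter), and adding a hydroxy where the ring had none gives an at least 5.9-fold lower number from compound 2 to compound 4 (0.77 log units; beyond the scatter), so this place in the series responds to substitution, which the two methoxy compounds alone could not show. The 2-hydroxy-3-methoxyphenyl group also goes past the 2-chlorophenyl reference, with a 2.3-fold lower number from compound 1 to compound 4 (0.36 log units; beyond the scatter). The first two of these steps each have one end at a limit and so give only a minimum size: the limit of > 166000 nM in this assay, at which 2 of the 4 values shown sit.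

From the compounds shown here alone, whether an amine in place of the hydroxy, or an ethyl group or a longer chain on that oxygen, would hold the value of compound 4 stays open. Also open, going by these compounds, is whether a 2-hydroxyphenyl group, without the methoxy, would keep the step.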